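A few compounds are considered here, and "the series" means these few. Any claim that something is new, unique, unknown or untested is made for them only; others in the source may bear on it.

Measured so far:
Compound 1 `CC[C@H](Nc1nc(NCc2ccccn2)c2ncn(C(C)C)c2n1)C(O)C(C)(C)C` — > 50000 nM (a limit)
Compound 2 `CCC(O)[C@H](CC)Nc1nc(NCc2ccccn2)c2ncn(C(C)C)c2n1` — 29000 nM

In a functional assay on HCT-116 cells (Homo sapiens) for inhibition, read by sulforhodamine B assay, with a stated time of 96 h (on this read-out lower numbers stand for stronger inhibition of growth and higher numbers for weaker inhibition of growth), compound 1 reaches only a limit, > 50000 nM. Compound 2 gives 29000 nM in this assay, the only number shown. For the measured compounds named here, the single measured step, an at least 1.7-fold lower number from compound 1 to compound 2 (0.23 log units; that floor lies within the scatter), exchanges one group for another and so does not speak to a change of configuration. Compound 3 `CCC(O)[C@@H](CC)Nc1nc(NCc2ccccn2)c2ncn(C(C)C)c2n1` differs from compound 2 thus: the two compounds have the same atoms and bonds; at least one stereo element is drawn with a configuration in one of them and without one in the other: 1 of 2 stereo elements differ; a stereocentre at a saturated chain carbon is drawn S in compound 2 and R in compound 3. Going by the values given here, with no measured step bearing on an inversion of a stereocentre, the size and direction of this step are unknown. Compound 3 is expected to sit near 50000 nM, with a range from 15000 nM to 150000 nM. The expected step is a 1.7-fold higher number from compound 2 to compound 3 (0.24 log units; within the scatter).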

Compound 3, concentration for 50% growth inhibition: 29000 nM
Compound 3: middle estimate off by 1.7-fold (0.24 log units), on the high side, and the stated range covers the measured number.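

In this assay, for the compounds shown here, the inversion at the saturated chain carbon gives no change at the digits printed from compound 2 to compound 3 (within the scatter) and so, unlike the earlier compounds, shows that drawing this stereocentre S or R leaves the number unmoved within the scatter. This reading comes with one qualification: the fact that one of compounds 2 and 3 is drawn with a defined configuration and the other without, at the place where they differ. The step of an at least 1.7-fold lower number from compound 1 to compound 3 (0.23 log units; that floor lies within the scatter) rests on the limit of compound 1 and gives only a floor: the limit of > 50000 nM in this assay, at which 1 of the 3 values shown sits.

The compounds shown leave open whether an amine in place of the oxygen on this chain, or a longer chain, would give a lower number.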